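A few compounds are considered here, and "the series" means these few. Any claim that something is new, unique, unknown or untested is made for them only; others in the source may bear on it.

Measured in a functional assay on PANC-1 cells (Homo sapiens) for antiproliferative activity, read by MTT assay, with a stated time of 48 h; a lower number here means a stronger inhibitor, a higher number a weaker inhibitor:
Compound 1 `COc1ccc(-c2c(Nc3ccc(F)cc3)c3ccc(OC)cc3oc2=O)cc1`: "not determined" (no result reported)
Compound 2 `COc1ccc(-c2c(Nc3ccc(C)c(O)c3)c3ccc(OC)cc3oc2=O)cc1`: 31300 nM

Going by the values given here, in this series, compound 2 stands alone on the numbers, since its 31300 nM is the only value available. Compound 1 offers no comparison, as its entry reads "not determined" (no result reported). Nothing therefore shows how far this read-out moves when the group on the nitrogen changes.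

Compound 3 `CCOc1ccc(Nc2c(-c3ccc(OC)cc3)c(=O)oc3cc(OC)ccc23)cc1` is the next to be considered, and it has not yet been measured in this assay. It keeps the core of compound 2 and carries 4-ethoxyphenyl in place of 3-hydroxy-4-methylphenyl on a nitrogen on an aromatic ring.

Among the compounds with values here, with no measured step to serve as a guide, no step beyond the scatter is expected in this assay, in either direction. Within the data shown here, the only anchor is compound 2 at 31300 nM, so the uncertainty stays wide. The expected value for compound 3 is 30000 nM, with an estimated range from 10000 nM to 90000 nM. This estimate means an expected change a 1.0-fold lower number from compound 2 to compound 3 (0.02 log units; within the scatter).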

Compound 3, half-maximal inhibitory concentration: 36100 nM
Beside the measured number, compound 3's estimate is 1.2-fold (0.08 log units) below it; low and high end bracket the measured number.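

Going by these compounds alone, the first measured step at this position comes from exchanging 3-hydroxy-4-methylphenyl for 4-ethoxyphenyl on a nitrogen on an aromatic ring: in this assay the change gives a 1.2-fold higher number from compound 2 to compound 3 (0.06 log units; within the scatter) and so does not separate the two groups. This holds even though the group leaving carries a hydrogen-bond donor and the group entering carries none, so for this one pair, losing that donor and exchanging the substituents around the ring leave the read-out within its usual scatter. No measurement is available that bears on why this pair gives such similar values.

Within the data shown here, compound 1 gives "not determined" (no result reported) in this assay, so the two numbers available remain the only guide to this position, and whether any group on this nitrogen can move the read-out beyond the scatter stays open. It is also unknown how a ring bearing an amine or a carboxylic acid, or a longer chain such as butoxy in place of the ethoxy group, would read in this assay, and the parts of the shared core outside this nitrogen remain untested by any step shown.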